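The source may hold more compounds than are shown below. What is called first, only, known or untested is meant among the compounds shown, and "the series" means these compounds.

Going by the values given here, compound 3 `CN1CCN(c2nc(-c3cc(Cl)ccc3Cl)nc3[nH]cnc23)CC1` is one of three compounds measured in an assay on cells for displacement of a labelled ligand from adenosine receptor A1 (Homo sapiens), read by scintillation counting and radioligand binding, with a stated time of 60 min, tested at 10 uM; on this read-out lower numbers stand for less inhibition and higher numbers for more inhibition at the one concentration tested (going by the name of the read-out). Compound 3 gives > 80%, which is a limit of the assay rather than a number, so its true read-out is not known beyond that. Compound 1 `CN1CCN(c2nc(-c3ccc(Cl)c(Cl)c3)nc3[nH]cnc23)CC1` also gives > 80%, again a limit. The step that the two limits leave unreadable from compound 1 to compound 3 therefore cannot be read, since both of its ends sit at the limit of > 80% in this assay, at which 2 of the 3 values shown sit. Compound 2 `Cn1cnc2c(N3CCCCC3)nc(-c3cc(Cl)ccc3Cl)nc21` gives 13.2% in this assay, a plain number.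

Compound 4 `Clc1ccc(Cl)c(-c2nc(N3CCCCC3)c3nc[nH]c3n2)c1` has not yet been measured. It differs from compound 3 in a single place: piperidin-1-yl in place of 4-methylpiperazin-1-yl on an aromatic carbon. None of the measured steps changes this group, so nothing shown gives the size of such a change directly. Compound 2, which also carries piperidin-1-yl, shows a low read-out, but it differs from compound 4 in a second place as well, so its value is only a hint rather than a measured step. On that hint, a drop from the limit is expected, and the step from compound 3 to compound 4 is estimated to be a number at least 35 percentage points lower from compound 3 to compound 4 (beyond the scatter). Compound 4 is therefore expected to give about 45%, somewhere between 10% and 80%.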

Compound 4, a percentage reported as inhibition, at one concentration (the size of the read-out at that concentration, not a potency): 1.4%
Beside the measured number, compound 4's estimate is 43.6 percentage points above it, outside the stated range (below it).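

In this assay, going by these compounds alone, the first measured change at this place, on an aromatic carbon next to the ring nitrogen, is a number at least 78.6 percentage points lower from compound 3 to compound 4 (beyond the scatter), so exchanging 4-methylpiperazin-1-yl for piperidin-1-yl, which removes one ring nitrogen and its methyl group, leaves almost no inhibition at the one concentration tested. The reading for compound 3 is a limit and not a number, so the true size of this step stays unknown: the limit of > 80% in this assay, at which 2 of the 4 values shown sit.

With piperidin-1-yl in place, hydrogen in place of methyl on an aromatic nitrogen gives a number 11.8 percentage points lower from compound 2 to compound 4 (beyond the scatter), so the methyl group on that nitrogen does not bring back a high read-out in this pair.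

The compounds shown leave open whether the high read-out depends on the second ring nitrogen or on its methyl group, a question that piperazin-1-yl carrying a hydrogen on that nitrogen, or morpholin-4-yl with an oxygen in place of that nitrogen, could help to separate. Also open, on these data alone, is what methyl on the aromatic nitrogen does when 4-methylpiperazin-1-yl is present, and the step between the two dichlorophenyl groups still cannot be read.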